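The source may hold more compounds than are shown below. What is called first, only, known or untested is meant among the compounds shown, and "the series" means these compounds.

The series shares the core of compound 1 `CCC(CC)O[C@@H]1C=C(C(=O)O)C[C@H](NCc2cccc(OC)c2)[C@H]1NC(C)=O`. In an ADME assay on cells (Fibroblast, Gallus gallus) for cytotoxicity, read by CCK-8 assay, with a stated time of 48 h (on this read-out lower numbers stand for higher toxicity in this test and higher numbers for lower toxicity in this test), compound 1 gives > 200000 nM, which is a limit of the assay and not a number. Compound 2 `CCC(CC)O[C@@H]1C=C(C(=O)O)C[C@H](NCc2ccc(SC(C)CC)cc2)[C@H]1NC(C)=O` in this assay gives > 200000 nM, again a limit rather than a number. Compound 2 therefore sits at the limit of > 200000 nM in this assay, at which 2 of the 2 values shown sit, and no step between measured compounds can be counted; on the numbers shown nothing separates it from compound 1.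

Compound 3 `CCC(CC)O[C@@H]1C=C(C(=O)O)C[C@H](NCc2ccc(S(=O)(=O)c3ccccc3)cc2)[C@H]1NC(C)=O` is not yet measured. Relative to compound 2 the change is phenylsulfonyl in place of (sec-butyl)sulfanyl on an aromatic carbon.

Among the compounds with values here, with both measured values at the limit, no measured step in this assay is available to anchor a direction. For compound 3 the expected step is a step that the limit leaves unreadable from compound 2 to compound 3, which is none beyond the scatter. Compound 3 in this assay is thus expected at about 250000 nM, within 100000 nM to 600000 nM, most likely reported again only as a limit.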

Compound 3, half-maximal cytotoxic concentration: > 200000 nM
Compound 3: a limit, no number; the forecaster's own chance of this, stated with the estimate: 80%; the middle value does not contradict the limit.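

In this assay, within the data shown here, compound 3 gives a limit and not a number, as compound 2 does, so no step between compound 2 and compound 3 can be read. The compounds shown leave open whether phenylsulfonyl in place of (sec-butyl)sulfanyl changes this read-out at all.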